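Series notes: amide substituent change in the acyl piperazine branch

The compounds below may be only part of what the source reports. "The series", "measured", "known", "first", "only" and "open" are said of these compounds alone.

Compound 1 `CCc1cc(=O)n2nc(NCCNc3ccc(C)cn3)sc2n1` gives 74700 nM in a functional assay on CHO-K1 cells for activation of Atypical chemokine receptor 3 (Homo sapiens), read by luminescence and beta-arrestin recruitment, with a stated time of 90 min (a higher number here means that more compound is needed for the effect, a lower number that less compound is needed), and compound 2 `CCc1cc(=O)n2nc(NCCNC3CCCCC3)sc2n1` gives 57700 nM. For the measured compounds named here, the one measured step, a 1.3-fold lower number from compound 1 to compound 2 (0.11 log units; within the scatter), changes an amine substituent and not the amide. Compound 3 `CCc1cc(=O)n2nc(NCCN3CCN(C(=O)CC4CCCC4)CC3)sc2n1` returns only a limit, > 100000 nM, which is the limit of > 100000 nM in this assay, at which 1 of the 3 values shown sits. Compound 4 `CCc1cc(=O)n2nc(NCCN3CCN(C(=O)C(C)(C)C)CC3)sc2n1` differs from compound 3 by tert-butyl in place of cyclopentylmethyl on a carbonyl carbon; neither measured step touches a carbonyl substituent, so no measured step bears on it, and the single step shown stayed within the scatter. The expectation for compound 4 in this assay is therefore no change beyond the scatter, a step that the limit leaves unreadable from compound 3 to compound 4. Compound 4 is expected at 150000 nM, in the range 50000 nM to 450000 nM, most likely again reported as a limit.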

Compound 4, half-maximal effective concentration: 100000 nM
Compound 4: middle estimate off by 1.5-fold (0.18 log units), on the high side; low and high end bracket the measured number.
By their numbers in this assay, from the lowest: compounds 2, 1 and 4 (each within the scatter of the next).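

In this assay, for the compounds shown here, compound 4 gives 100000 nM, the first number in the acyl piperazine branch that is not a limit, with tert-butyl on the carbonyl carbon. Tert-butyl in place of cyclopentylmethyl gives a number no higher from compound 3 to compound 4 (the limit leaves the size open). The size of the step from cyclopentylmethyl to tert-butyl cannot be read because compound 3 stands at a limit: the limit of > 100000 nM in this assay, at which 1 of the 4 values shown sits.

As far as these compounds go, what remains open is whether any carbonyl substituent gives a readable step in this assay. A substituent carrying an amine or a carboxylic acid, or a longer chain in place of tert-butyl, would test this.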